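Amino substitution on the benzimidazole-bearing quinolone pair

The source may report more compounds than this note shows. Statements on the series, on what has been measured and on what is new or still open speak of the compounds shown alone.

Measured compounds:
- compound 1, `CCn1cc(-c2nc3ccccc3[nH]2)c(=O)c2cc(F)c(N3CCNCC3)cc21`: 9500 nM
- compound 2, `CCn1cc(-c2nc3ccccc3[nH]2)c(=O)c2cc(F)c(N3CCNCC3)nc21`: 2100 nM
- compound 3, `CCn1cc(-c2nc3ccc(N)cc3[nH]2)c(=O)c2cc(F)c(N3CCNCC3)cc21`: 7800 nM

All three were run in a functional assay on AGS cells (Homo sapiens) for cytotoxicity, read by sulforhodamine B assay, with a stated time of 48 h; a lower number here means a stronger inhibitor of growth, a higher number a weaker inhibitor of growth. Compound 1 gives 9500 nM and compound 3 gives 7800 nM; the change between them is amino in place of hydrogen on an aromatic carbon, and the resulting step, a 1.2-fold lower number from compound 1 to compound 3 (0.09 log units; within the scatter), is within the scatter, so the two numbers are not distinguished here. Compound 2 differs from compound 1 in the core, and the difference between the two cores is not broken down here. In this assay compound 2 gives 2100 nM, the lowest of the three numbers, with both other compounds beyond the scatter from it.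

Compound 4, `CCn1cc(-c2nc3ccc(N)cc3[nH]2)c(=O)c2cc(F)c(N3CCNCC3)nc21`, is not yet measured. It differs from compound 2 by amino in place of hydrogen on an aromatic carbon, the same change that was made from compound 1 to compound 3, at a place described in identical words. Among the compounds with values here, the only guide is that single earlier step, which did not move the number beyond the scatter. The step from compound 2 to compound 4 is therefore expected to be small, a 1.2-fold lower number from compound 2 to compound 4 (0.07 log units; within the scatter), resting on a 1.2-fold lower number from compound 1 to compound 3 (0.09 log units; within the scatter) and on the value of compound 2, 2100 nM. Compound 4 is estimated at 1800 nM in this assay, with a range from 700 nM to 4500 nM; one earlier step on a different core is a thin base for this expectation.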

Compound 4, concentration for 50% growth inhibition: 6700 nM
Beside the measured number, compound 4's estimate is 3.7-fold (0.57 log units) below it, and the stated range ends below it.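

In this assay, amino in place of hydrogen on an aromatic carbon gives a 3.2-fold higher number from compound 2 to compound 4 (0.50 log units; beyond the scatter), so the step does not carry over unchanged from the core of compound 1 to the core of compound 2, and the two readings of the same change differ: the same change on two cores in this assay, a 1.2-fold lower number (0.09 log units; within the scatter) from compound 1 to compound 3 and a 3.2-fold higher number (0.50 log units; beyond the scatter) from compound 2 to compound 4, 3.9-fold (0.59 log units) apart, beyond the scatter of two such steps

For this series, the size of the step therefore depends on the core it is made on, at least for this pair of cores, and a step read on one core is a poor stand-in for the other; with the amino group present, compound 3 gives 7800 nM and compound 4 gives 6700 nM. The comparison does not show why the two steps differ, it rests on a single pair of steps in one cell line, and it says nothing on whether the same dependence on the core would appear with any other group or at any other place on the ring.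

Still open, as far as these compounds go, is whether a hydroxyl or a methoxy group on the same aromatic carbon would follow the amino group on each core. Equally open, from the compounds shown here alone, is whether an acetylated amine there would keep the gap between the two steps or close it.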